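A nitro for a methyl in a level series

The source may hold more compounds than are shown below. What is called first, only, known or untested is meant among the compounds shown, and "the series" means these compounds.

Compound 1 `O=C1/C(=C/c2cccnc2)CNC/C1=C\c1ccccc1F` gives 15900 nM
Compound 2 `O=C1/C(=C/c2cccnc2)CN(S(=O)(=O)c2ccccc2)C/C1=C\c1ccccc1F` gives 15300 nM
Compound 3 `Cc1ccc(S(=O)(=O)N2C/C(=C\c3cccnc3)C(=O)/C(=C/c3ccccc3F)C2)cc1` gives 14900 nM

These three values come from an ADME assay on L02 cells (Homo sapiens) for cytotoxicity, read by MTT assay, with a stated time of 24 h (a lower number here means a stronger inhibitor, a higher number a weaker inhibitor), and do not separate. Compound 3 stands level with the other two, as the steps show (a 1.0-fold lower number from compound 2 to compound 3 (0.01 log units; within the scatter)) and (a 1.1-fold lower number from compound 1 to compound 3 (0.03 log units; within the scatter)). Compound 4 `O=C1/C(=C/c2cccnc2)CN(S(=O)(=O)c2ccc([N+](=O)[O-])cc2)C/C1=C\c1ccccc1F` has nitro in place of methyl on an aromatic carbon, para to a large group (nitro in place of methyl on an aromatic carbon). The cut one bond further out reads 4-methylphenyl to 4-nitrophenyl. Among the measured compounds shown here, no measured compound carries nitro, so the data hold no direct precedent. The nearest evidence is methyl in place of hydrogen on that aromatic carbon (a 1.0-fold lower number from compound 2 to compound 3 (0.01 log units; within the scatter)). Adding phenylsulfonyl to the amine nitrogen in the ring also stayed within the scatter (a 1.0-fold lower number from compound 1 to compound 2 (0.02 log units; within the scatter)). In this assay no step beyond the scatter is therefore expected, and the estimated step is small (a 1.1-fold lower number from compound 3 to compound 4 (0.03 log units; within the scatter)). Compound 4 is estimated at 14000 nM with a range of 7000 nM to 26000 nM as expected bounds.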

Compound 4, half-maximal inhibitory concentration: > 20000 nM
Compound 4 ended at the assay's limit (the forecaster's own chance of this, stated with the estimate: 3%); middle value at least 1.4-fold (0.15 log units) away from the limit.
By their numbers in this assay, from the lowest: compounds 3, 2 and 1 (each within the scatter of the next). At a limit, above all of these: compound 4.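

In this assay compound 4 reads > 20000 nM, which is a limit of the assay and not a number: the limit of > 20000 nM in this assay, at which 1 of the 4 values shown sits. On the aromatic carbon para to a large group, where methyl had left the series level, nitro gives an at least 1.3-fold higher number from compound 3 to compound 4 (0.12 log units; that floor lies within the scatter), and set against hydrogen at the same carbon it gives an at least 1.3-fold higher number from compound 2 to compound 4 (0.11 log units; that floor lies within the scatter). Compound 4 is thus the only one of the series to reach the limit, but both floors lie within the scatter, so the change is not shown to exceed it.

The compounds shown leave open how far the true value of compound 4 lies from the others. They also leave open whether an amine or a carboxylic acid on that aromatic carbon would stay level with compound 3 or reach the limit too.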